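A few compounds are considered here, and "the series" means these few. Any claim that something is new, unique, unknown or untested is made for them only; others in the source may bear on it.

Compound 1 `CCN(CC)c1ccc(-c2cccc(C#N)c2)nn1` and compound 2 `CCN(CC)c1ccc(-c2ccc(C#N)cc2)nn1` have the same atoms joined differently; the difference between the two cores is not broken down here. In a functional assay on MDA-MB-231 cells (Homo sapiens) for antiproliferative activity, with a stated time of 48 h (a lower number here means a stronger inhibitor, a higher number a weaker inhibitor), compound 1 gives only a limit, > 25000 nM. Compound 2 also gives only a limit, > 25000 nM. Compound 3 `CCOC(=O)c1ccc(-c2ccc(N(CC)CC)nn2)cc1` carries ethoxycarbonyl in place of cyano on an aromatic carbon and in this assay gives 1500 nM; the measured step is an at least 16-fold lower number from compound 2 to compound 3 (1.22 log units; beyond the scatter), read against (the limit of > 25000 nM in this assay, at which 2 of the 3 values shown sit). Compound 4 `CCOC(=O)c1cccc(-c2ccc(N(CC)CC)nn2)c1` carries ethoxycarbonyl in place of cyano on an aromatic carbon, the same kind of change, though here the place is meta to a large group where for compound 3 it is para to a large group. For compound 4 the expected step is an at least 5.0-fold lower number from compound 1 to compound 4 (0.69 log units; beyond the scatter), smaller and less certain than the earlier one, resting on an at least 16-fold lower number from compound 2 to compound 3 (1.22 log units; beyond the scatter) with the place shifted. Compound 4 is estimated at 5000 nM, expected between 1200 nM and 25000 nM.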

Compound 4, half-maximal inhibitory concentration: > 25000 nM
Compound 4: only a limit was reported; the forecaster's own chance of this, stated with the estimate: 30%; middle value at least 5.0-fold (0.69 log units) from the limit.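

Compound 1 and compound 4 both give only a limit, so no step between them can be read: the limit of > 25000 nM in this assay, at which 3 of the 4 values shown sit.

As far as these compounds go, whether ethoxycarbonyl in place of cyano, meta to a large group, lowers the number at all remains open.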